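The source may hold more compounds than are shown below. What is called first, only, known or untested is meant among the compounds shown, and "the series" means these compounds.

Of the compounds shown here, three have been measured so far in a functional assay, with a stated time of 20 min; on this read-out lower numbers stand for stronger inhibition and higher numbers for weaker inhibition. Compound 1 `CCOC(=O)c1cnn(-c2nc(-c3ccccc3O)c(C#N)c(=O)n2C)c1N` gives 48 ug/mL in this assay. Compound 2 `COc1cccc(-c2nc(NN)n(C)c(=O)c2C#N)c1OC` gives 44 ug/mL, and compound 3 `COc1cccc(-c2nc(SC)n(C)c(=O)c2C#N)c1OC` gives 54 ug/mL. Compound 1 sits among these three numbers with no separation from either of the others: its gap to compound 2 and its gap to compound 3 both lie within the scatter of repeated measurements, so none of the three can be called stronger or weaker than another. Among the compounds with values here, the only single-point step among the measured compounds, a 1.2-fold higher number from compound 2 to compound 3 (0.09 log units; within the scatter), also stays within the scatter.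

Compound 4 `CCOC(=O)c1cnn(-c2nc(-c3cccc(O)c3O)c(C#N)c(=O)n2C)c1N` has not yet been measured. It differs from compound 1 in one place: hydroxy in place of hydrogen on an aromatic carbon.

Within the data shown here, no measured step bears directly on this change. The step from compound 2 to compound 3 concerns a different group on a different part of the shared core, and it was within the scatter, so it offers no direction for adding a hydroxy group. With nothing in the measured set pointing either way, compound 4 is expected to stay close to compound 1, with an estimated step of a 1.0-fold lower number from compound 1 to compound 4 (0.02 log units; within the scatter), nothing beyond the scatter. The estimate for compound 4 in this assay is therefore 46 ug/mL, with a range from 20 ug/mL to 105 ug/mL.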

Compound 4, half-maximal inhibitory concentration: 41 ug/mL
Compound 4: middle estimate off by 1.1-fold (0.05 log units), on the high side; low and high end bracket the measured number.
By their numbers in this assay, from the lowest: compounds 4, 2, 1 and 3 (each within the scatter of the next).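

The change from 2-hydroxyphenyl to 2,3-dihydroxyphenyl is the only step among the compounds shown that alters this aromatic ring by a single group, and in this assay it stays within the scatter (a 1.2-fold lower number from compound 1 to compound 4 (0.07 log units; within the scatter)). A hydroxy group can therefore stand on this aromatic carbon, ortho to the existing hydroxy group, and the two compounds still cannot be told apart on this read-out. For this position, then, the data show no readable gain or loss from this one added group, and nothing measured on these compounds goes further to explain that outcome.

A single small group at one position cannot show whether this carbon tolerates every substituent, so a carboxylic acid or a longer chain such as propoxy could still separate clearly from compound 1. Within the data shown here, what the remaining carbons of this aromatic ring would do with such groups also stays open, since the one step here speaks only for hydroxy at this single place.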